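Diaryl ether thiophene sulfonamides: methoxy versus hydroxy at the aryloxy ring

The source may report more compounds than this note shows. Statements on the series, on what has been measured and on what is new or still open speak of the compounds shown alone.

Compound 1 `COc1ccc(Oc2ccccc2-c2ccsc2S(=O)(=O)NCCNC(=S)Nc2cc(C(F)(F)F)cc(C(F)(F)F)c2)cc1OC` carries a 3,4-dimethoxyphenyl on the aryl ether oxygen; in a functional assay on HeLa cells (Homo sapiens) for inhibition, read by CCK-8 assay, with a stated time of 48 h (on this read-out lower numbers stand for stronger inhibition and higher numbers for weaker inhibition), compound 1 gives 6400 nM. Compound 3 `O=S(=O)(NCCNC(=S)Nc1cc(C(F)(F)F)cc(C(F)(F)F)c1)c1sccc1-c1ccccc1Oc1ccc(O)c(O)c1` is its 3,4-dihydroxyphenyl counterpart. In this assay compound 3 returns only a limit of the assay, > 50000 nM. The change 3,4-dimethoxyphenyl in place of 3,4-dihydroxyphenyl on an oxygen on an aromatic ring therefore produces an at least 7.8-fold lower number from compound 3 to compound 1 (0.89 log units; beyond the scatter), and the true size of that step is open at the upper end because the limit of > 50000 nM in this assay, at which 2 of the 3 values shown sit, is all that the measurement of compound 3 gives.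

Compound 2 `CC(C)c1ccc(Oc2ccc(O)c(O)c2)c(-c2ccsc2S(=O)(=O)NCCNC(=O)Nc2cc(C(F)(F)F)cc(C(F)(F)F)c2)c1` shares the dihydroxyphenyl ether of compound 3, but the difference between the two cores is not broken down here. In this assay compound 2 also returns only a limit, > 50000 nM. Compound 4 `COc1ccc(Oc2ccc(C(C)C)cc2-c2ccsc2S(=O)(=O)NCCNC(=O)Nc2cc(C(F)(F)F)cc(C(F)(F)F)c2)cc1OC` is to be measured in this assay; it differs from compound 2 by 3,4-dimethoxyphenyl in place of 3,4-dihydroxyphenyl on an oxygen on an aromatic ring, the same change in the same place as from compound 3 to compound 1. Applying a step of comparable size, the expected change from compound 2 to compound 4 is an at least 3.3-fold lower number from compound 2 to compound 4 (0.52 log units; beyond the scatter); the starting point being a limit makes this uncertain. Compound 4 is estimated at 15000 nM, within 4000 nM to 60000 nM.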

Compound 4, half-maximal inhibitory concentration: 11600 nM
Beside the measured number, compound 4's estimate is 1.3-fold (0.11 log units) above it; measured number inside the range.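

In this assay, 3,4-dimethoxyphenyl in place of 3,4-dihydroxyphenyl on an oxygen on an aromatic ring again lowers the number on a second core, giving an at least 4.3-fold lower number from compound 2 to compound 4 (0.63 log units; beyond the scatter). The direction therefore carries over in both pairs shown, with neither going against it, but the size of the step is not established on either core: the same change on two cores in this assay, an at least 7.8-fold lower number (0.89 log units; beyond the scatter) from compound 3 to compound 1 and an at least 4.3-fold lower number (0.63 log units; beyond the scatter) from compound 2 to compound 4; the limit leaves it open whether they differ. Two pairs do not make a rule for the whole series, and neither dihydroxy compound gives a number to measure from: the limit of > 50000 nM in this assay, at which 2 of the 4 values shown sit.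

The compounds shown leave open whether both methoxy groups are needed, since the only groups compared at this place are 3,4-dihydroxyphenyl and 3,4-dimethoxyphenyl. Also open, on these data alone, is how a phenyl carrying a single methoxy group, an amine or a carboxylic acid would read at the same oxygen, and whether any such group would follow the same direction on both cores.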